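The source may report more compounds than this note shows. Statements on the series, on what has been measured and on what is new or still open speak of the compounds shown alone.

In a functional assay on MKN-45 cells (Homo sapiens) for inhibition, read by CCK-8 assay, with a stated time of 24 h (a lower number here means a stronger inhibitor, a higher number a weaker inhibitor), compound 1 `O=C1Nc2ccccc2/C1=C/c1ccc(-c2cn(-c3ccc(Cl)c(C(F)(F)F)c3)nn2)cc1` gives 8890 nM and compound 2 `Cc1cccc(-n2cc(-c3ccc(/C=C4\C(=O)Nc5ccc(F)cc54)cc3)nn2)c1` gives 6810 nM. These two numbers lie within the scatter of each other, so compound 2 does not stand apart on the data so far. Compound 3 `N#Cc1cccc(-n2cc(-c3ccc(/C=C4\C(=O)Nc5ccc(F)cc54)cc3)nn2)c1` differs from compound 2 in one place, with 3-methylphenyl becoming 3-cyanophenyl: cyano in place of methyl on an aromatic carbon. For the measured compounds named here, no measured pair shows what this swap does, so no shift beyond the scatter is expected in either direction. The estimated step of a 1.1-fold lower number from compound 2 to compound 3 (0.05 log units; within the scatter) is therefore small. For compound 3 the estimated value is 6000 nM, with an expected range from 2000 nM to 18000 nM.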

Compound 3, half-maximal inhibitory concentration: > 20000 nM
Compound 3 was reported as a limit; the forecaster's own chance of this, stated with the estimate: 5%; middle value at least 3.3-fold (0.52 log units) from the limit.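

Replacing methyl with cyano on this aromatic carbon, meta to a large group, gives an at least 2.9-fold higher number from compound 2 to compound 3 (0.46 log units; beyond the scatter) in this assay. For the compounds shown here, this is the first single change here that reads beyond the scatter, and it shows that the two groups are not interchangeable at this position. Compound 3 has a limit rather than a number, so the full size of the step stays unknown: the limit of > 20000 nM in this assay, at which 1 of the 3 values shown sits.

Only methyl and cyano can be compared at this position. From the compounds shown here alone, how a methoxy group or an amine would behave here remains open, as does whether cyano elsewhere on the ring would give a similar step.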